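Metabolic stability after a sulfone-for-acid exchange on the amide

The source may report more compounds than this note shows. Statements on the series, on what has been measured and on what is new or still open speak of the compounds shown alone.

Measured compounds:
compound 1 `CCC[C@]1(C(=O)N2CC[C@](c3ccc(C(F)(C(F)(F)F)C(F)(F)F)cc3)(S(=O)(=O)c3ccc(F)cc3)C2)CC[C@H](C(=O)O)CC1` — "not determined" (no result reported)
compound 2 `O=C(O)[C@H]1CC[C@](F)(C(=O)N2CC[C@](c3ccc(C(F)(C(F)(F)F)C(F)(F)F)cc3)(S(=O)(=O)c3ccc(F)cc3)C2)CC1` — "not determined" (no result reported)
compound 3 `O=C1NC(=O)C2(CCC(C(=O)N3CC[C@](c4ccc(C(F)(C(F)(F)F)C(F)(F)F)cc4)(S(=O)(=O)c4ccc(F)cc4)C3)CC2)N1` — 84%; 93% (2 entries)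

In an ADME assay on microsomes from liver (Homo sapiens) for metabolic stability, with a stated time of 10 min (a lower number here means that less of the compound is left, a higher number that more of the compound is left), compound 3 gives 84%; 93% (2 entries), a pair of entries that agree with each other within the usual scatter (the several entries of compound 3 in this assay, 84%; 93% (2 entries)). Compound 2 has no number here; its entries carry no single value, so its standing rests on the shared core alone. Compound 4 `O=C(C1CCS(=O)(=O)CC1)N1CC[C@](c2ccc(C(F)(C(F)(F)F)C(F)(F)F)cc2)(S(=O)(=O)c2ccc(F)cc2)C1` has not yet been measured. It differs from compound 2 in one place: 1,1-dioxothian-4-yl in place of 4-carboxy-1-fluorocyclohexyl on a carbonyl carbon. Going by the values given here, no measured pair spans such a change, so the size of the step from compound 2 to compound 4 in this assay cannot be read from the data; a change within the scatter or a modest shift either way seems equally plausible. Compound 4 is expected to give 75%, within a range from 50% to 95%.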

Compound 4, percent of the compound remaining: 93%
Estimate against measurement, compound 4: 18 percentage points below, and the stated range covers the measured number.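

Going by these compounds alone, with no single number for compound 2, no step to compound 4 can be read from this result. The compounds shown leave open how exchanging 4-carboxy-1-fluorocyclohexyl for 1,1-dioxothian-4-yl on the carbonyl carbon affects the percent of compound remaining.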